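A few compounds are considered here, and "the series" means these few. Any claim that something is new, unique, unknown or untested is made for them only; others in the source may bear on it.

Compound 1 `Cc1cccc(-c2nc(C)c(COc3ccc4c(c3)OCC4CC(=O)O)s2)c1` and compound 2 `COc1ccc(-c2nc(C)c(COc3ccc4c(c3)OCC4CC(=O)O)s2)cc1` share one core and differ only in the aryl group carried on the five-membered ring. In a functional assay on CHO cells for agonist activity at Free fatty acid receptor 1 (Homo sapiens), read by FLIPR and calcium flux, tested at 100 nM (a higher number here means a stronger effect of the compound at the concentration tested, a lower number a weaker effect), compound 1 gives 47.2%, and compound 2 gives 46.8%; that leaves compound 2 with the lower of the two numbers, but only by a number 0.4 percentage points lower from compound 1 to compound 2 (within the scatter), so the two compounds stand level. Compound 3 `COc1cc(OC)cc(-c2nc(C)c(COc3ccc4c(c3)OCC4CC(=O)O)s2)c1` follows the same line: it carries 3,5-dimethoxyphenyl in place of 4-methoxyphenyl on an aromatic carbon. Among the measured compounds shown here, the only step that bears on this change is the one from compound 1 to compound 2, an exchange of aryl groups at the same carbon that moved the read-out by a number 0.4 percentage points lower from compound 1 to compound 2 (within the scatter). On that basis compound 3 is expected to sit close to compound 2, with a step of a number 1.8 percentage points lower from compound 2 to compound 3 (within the scatter) that stays inside the scatter. The estimate for compound 3 in this assay is 45%, within 30% to 60%.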

Compound 3, a percentage reported as activity, at one concentration (the size of the read-out at that concentration, not a potency): 17.5%
Compound 3: the middle estimate sits 27.5 percentage points above what was measured; measured number outside the range, below it.
By their numbers in this assay, from the lowest: compound 3; then compounds 2 and 1 (each within the scatter of the next).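

On the carbon of the five-membered ring next to the ring sulfur, the aryl exchange is no longer silent in this assay: 3,5-dimethoxyphenyl in place of 4-methoxyphenyl gives a number 29.3 percentage points lower from compound 2 to compound 3 (beyond the scatter), and in place of 3-methylphenyl it gives a number 29.7 percentage points lower from compound 1 to compound 3 (beyond the scatter). The earlier exchange of 3-methylphenyl for 4-methoxyphenyl, at a number 0.4 percentage points lower from compound 1 to compound 2 (within the scatter), had shown no sensitivity at this position, so the result shows that the read-out does depend on the aryl group carried there. Nothing available explains this loss.

The compounds shown leave open whether the loss follows from the second methoxy group or from the arrangement of substituents. A 3-methoxyphenyl or a 3,5-dimethylphenyl group on the same carbon would bear on that question.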